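Chain length and aryl swap in alpha-1 binding

The compounds below may be only part of what the source reports. "The series", "measured", "known", "first", "only" and "open" are said of these compounds alone.

Measured so far:
compound 1 `O=C1CC(=C(c2ccccc2)c2ccccc2)C(=O)N1CCN1CCN(c2cccc(C(F)(F)F)c2)CC1`, > 1000 nM
compound 2 `O=C1CC(=C(c2ccccc2)c2ccccc2)C(=O)N1CCN1CCN(c2ccc(F)cc2)CC1`, 529 nM
compound 3 `O=C1CC(=C(c2ccccc2)c2ccccc2)C(=O)N1CCCN1CCN(c2cccc(C(F)(F)F)c2)CC1`, 62.7 nM

In an assay on membranes from Cerebral cortex for binding affinity to Adrenergic receptor alpha-1 (Rattus norvegicus), read by radioligand binding (a lower number here means a stronger inhibitor, a higher number a weaker inhibitor), compound 1 gives only a limit, not a number (the limit of > 1000 nM in this assay, at which 1 of the 3 values shown sits). Compound 2 gives 529 nM in this assay. The change from compound 1 to compound 2 is 4-fluorophenyl in place of 3-(trifluoromethyl)phenyl on an amine nitrogen in a ring, and it made an at least 1.8-fold lower number from compound 1 to compound 2 (0.27 log units; that floor lies within the scatter). Compound 3 gives 62.7 nM, the lowest of the two numbers. How the core of compound 3 differs from that of compound 1 is not broken down here.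

Compound 4 `O=C1CC(=C(c2ccccc2)c2ccccc2)C(=O)N1CCCN1CCN(c2ccc(F)cc2)CC1` is not yet measured. It is reached from compound 3 by 4-fluorophenyl in place of 3-(trifluoromethyl)phenyl on an amine nitrogen in a ring, the same change as from compound 1 to compound 2. Because that earlier step was an at least 1.8-fold lower number from compound 1 to compound 2 (0.27 log units; that floor lies within the scatter), a step of similar size, a 1.4-fold lower number from compound 3 to compound 4 (0.14 log units; within the scatter), is expected here. Compound 4 is therefore estimated at 45 nM in this assay, most likely between 15 nM and 150 nM.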

Compound 4, inhibition constant: 8.3 nM
Beside the measured number, compound 4's estimate is 5.4-fold (0.73 log units) above it; measured number below the stated range.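

In this assay, placing 4-fluorophenyl where 3-(trifluoromethyl)phenyl stood gave a 7.6-fold lower number from compound 3 to compound 4 (0.88 log units; beyond the scatter). Set beside the earlier step, the number falls on both cores, but the sizes cannot be compared: the same change on two cores in this assay, an at least 1.8-fold lower number (0.27 log units; that floor lies within the scatter) from compound 1 to compound 2 and a 7.6-fold lower number (0.88 log units; beyond the scatter) from compound 3 to compound 4; the limit leaves it open whether they differ. Compound 1 gives > 1000 nM, which is a limit and not a number, so these two cores show a shared direction only, not a shared size and not a rule for other cores.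

The compounds shown leave open whether the swap would still lower the number on a core with a longer chain. They also leave open how an unsubstituted phenyl on the same amine nitrogen would compare with these two aryl groups.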